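Extending the acyl group of compound 1

A few compounds are considered here, and "the series" means these few. Any claim that something is new, unique, unknown or untested is made for them only; others in the source may bear on it.

Compound 1 `CC(=O)N1c2ccccc2CCC1C(=O)Nc1cc(C(F)(F)F)cc(C(F)(F)F)c1` was tested in a functional assay on MDA-MB-231 cells (Homo sapiens) for cytotoxicity, read by sulforhodamine B assay, with a stated time of 72 h; a higher number here means a weaker inhibitor of growth, a lower number a stronger inhibitor of growth. In that test compound 1 gives > 70000 nM, which is a limit of the assay rather than a measured number. Going by the values given here, the line the limit of > 70000 nM in this assay, at which 1 of the 3 values shown sits, notes that it is the only one of the three values sitting at that limit. Two further compounds give numbers. Compound 2 `O=C(Nc1ccccc1C(F)(F)F)C1CCc2ccccc2N1C(=O)c1ccccc1Cl` gives 2530 nM in this assay. Compound 3 `CCCCCCCCC(=O)N1c2ccccc2CCC1C(=O)Nc1ccccc1O` gives 54300 nM in this assay. Compound 4 `CCCC(=O)N1c2ccccc2CCC1C(=O)Nc1cc(C(F)(F)F)cc(C(F)(F)F)c1` has not yet been measured. It differs from compound 1 in one place: ethyl in place of hydrogen on a saturated chain carbon bound to a carbonyl carbon. Among the compounds with values here, no pair among the measured compounds differs in a single place, so no measured step guides this change directly; the only hint is that compound 3, with a long chain on the same carbonyl, gives 54300 nM. The step expected here, an at least 1.4-fold lower number from compound 1 to compound 4 (0.14 log units; that floor lies within the scatter) in this assay, is estimated to be small and toward stronger growth inhibition, if anything. Compound 4 is expected to give about 50000 nM, with a range from 15000 nM to 150000 nM.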

Compound 4, concentration for 50% growth inhibition: 15200 nM
Compound 4: the middle estimate sits 3.3-fold (0.52 log units) above what was measured, within the range that was stated.
By their numbers in this assay, from the lowest: compound 2; then compound 4; then compound 3. At a limit, above all of these: compound 1.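

In this assay, ethyl in place of hydrogen on a saturated chain carbon bound to a carbonyl carbon gives an at least 4.6-fold lower number from compound 1 to compound 4 (0.66 log units; beyond the scatter). This shows that the position responds to change: with the rest of the molecule held fixed, going from acetyl to propylcarbonyl is enough to bring growth inhibition into the range where a number can be read. Compound 1 stands at a limit of the assay, so this step is only a floor and its true size stays unknown: the limit of > 70000 nM in this assay, at which 1 of the 4 values shown sits.

Compounds 2 and 3 differ from compound 4 in more than one place, so they cannot show how the trend continues. On these data alone, whether a longer chain on the same carbonyl, or an amine at the end of the propyl group, would lower the number further remains open.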